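Swapping a Sulfur Link for a Benzylamine on a Shared Core

A few compounds are considered here, and "the series" means these few. Any claim that something is new, unique, unknown or untested is made for them only; others in the source may bear on it.

Of the compounds shown here, three built on one shared core have been tested in a functional assay on NCI-H322M cells (Homo sapiens) for inhibition, read by sulforhodamine B assay, with a stated time of 48 h; on this read-out higher numbers stand for weaker inhibition of growth and lower numbers for stronger inhibition of growth. Compound 2, `Nc1cc(N)c2nc(-c3ccccc3)c(Sc3ccc(F)cc3)nc2c1`, gives 20400 nM and stands second highest of the three numbers. Compound 1, `CCOC(=O)[C@H](CCC(=O)O)NC(=O)c1ccc(Sc2nc3cc(N)cc(N)c3nc2-c2ccccc2)cc1`, gives 34700 nM, which lies within the scatter of the value of compound 2, so the two cannot be told apart. Compound 3, `COc1cc(CNc2nc3cc(N)cc(N)c3nc2-c2ccccc2)cc(OC)c1OC`, gives 3020 nM, a gap beyond the scatter, so compound 3 inhibits growth more strongly than compound 2.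

Compound 4, `Nc1cc(N)c2nc(-c3ccccc3)c(NCc3ccc(F)cc3)nc2c1`, has not yet been measured. It differs from compound 2 in one place: (4-fluorobenzyl)amino in place of (4-fluorophenyl)sulfanyl on an aromatic carbon. The group that enters brings one hydrogen-bond donor where the group that leaves had none, and the attachment sits next to the ring nitrogen.

Within the data shown here, no pair of measured compounds differing in just one place is available, so the size of this step must be judged indirectly. Compound 3 also carries a benzylamino link to the core and gives 3020 nM, the lowest number seen, so a move toward stronger inhibition is expected. The step from compound 2 to compound 4 is estimated as a 2.9-fold lower number from compound 2 to compound 4 (0.46 log units; beyond the scatter). Compound 4 is therefore expected to give about 7000 nM, with a likely range from 2000 nM to 25000 nM.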

Compound 4, concentration for 50% growth inhibition: 3470 nM
Compound 4: the middle estimate sits 2.0-fold (0.30 log units) above what was measured; the measured number falls inside the stated range.
By their numbers in this assay, from the lowest: compounds 3 and 4 (each within the scatter of the next); then compounds 2 and 1 (each within the scatter of the next).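

In this assay, among these compounds, the earlier compounds offered no pair differing in one place, and this pair gives the first direct reading at this position: on the aromatic carbon next to the ring nitrogen, (4-fluorobenzyl)amino in place of (4-fluorophenyl)sulfanyl gives a 5.9-fold lower number from compound 2 to compound 4 (0.77 log units; beyond the scatter), so growth inhibition is stronger with the entering group. The change has more than one part, since the sulfur link gives way to an amino link with a methylene spacer and a hydrogen-bond donor appears where the leaving group had none, while the fluorinated ring stays, so this single step cannot show which part of the change matters. Nothing measured here accounts for the difference.

As far as these compounds go, what stays open is how the two parts of the change separate: a (4-fluorophenyl)amino group would keep the nitrogen without the methylene spacer, and a (4-fluorobenzyl)sulfanyl group would keep the spacer with the sulfur. Also open, from the compounds shown here alone, is how an N-methyl amine, with a methyl group on the link nitrogen in place of its hydrogen, would compare with compound 4.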